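Hydrazone variants on a shared core: from methoxyphenyl to pyrrolyl

The source may hold more compounds than are shown below. What is called first, only, known or untested is meant among the compounds shown, and "the series" means these compounds.

Measured compounds:
compound 1 `CC1=CC[C@H](C(C)(C)N=C=S)CC1` 4000 nM
compound 2 `COc1ccc(/C=N/NC(=S)NC(C)(C)[C@H]2CC=C(C)CC2)cc1` 1500 nM
compound 3 `CC1=CC[C@H](C(C)(C)NC(=S)N/N=C/c2cccc([N+](=O)[O-])c2)CC1` 45600 nM

In a functional assay on K562 cells (Homo sapiens) for inhibition, read by sulforhodamine B assay, with a stated time of 48 h (on this read-out higher numbers stand for weaker inhibition of growth and lower numbers for stronger inhibition of growth), compound 2 gives the lowest number of the three; compound 1 gives 4000 nM, a gap beyond the scatter, and compound 3 gives 45600 nM, far weaker. Compound 4 `CC1=CC[C@H](C(C)(C)NC(=S)N/N=C/c2ccc[nH]2)CC1` is not yet measured. The change from compound 2 is 1H-pyrrol-2-yl in place of 4-methoxyphenyl on a carbon with a double bond to nitrogen. Among the compounds with values here, no comparable step exists among the measured compounds; the only aryl variation seen, compound 2 to compound 3, points toward weaker growth inhibition when the 4-methoxyphenyl is replaced. The expected step from compound 2 to compound 4 is a 2.0-fold higher number from compound 2 to compound 4 (0.30 log units; within the scatter), a modest loss at most, possibly within the scatter. Compound 4 is estimated at 3000 nM, with a range from 800 nM to 12000 nM.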

Compound 4, concentration for 50% growth inhibition: 23400 nM
The estimate for compound 4 lay 7.8-fold (0.89 log units) below the measured number, outside the stated range (above it).
By their numbers in this assay, from the lowest: compound 2; then compound 1; then compounds 4 and 3 (each within the scatter of the next).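

In this assay, 1H-pyrrol-2-yl in place of 4-methoxyphenyl on a carbon with a double bond to nitrogen brings a large loss, a 16-fold higher number from compound 2 to compound 4 (1.19 log units; beyond the scatter), so this position does not accept the five-membered ring as an equal swap. Compound 4 at 23400 nM and compound 3 at 45600 nM lie within the scatter of each other, and both sit far from compound 2. Nothing given here bears on why the number rises. Still open, as far as these compounds go, is whether the loss follows the methoxy group or the six-membered ring. An unsubstituted phenyl or a 4-hydroxyphenyl at this place would separate the two.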